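The source may hold more compounds than are shown below. What is called first, only, known or untested is meant among the compounds shown, and "the series" means these compounds.

Compound 2, `CC1CC/C(=N\Nc2ccc(Cl)cc2)c2ncc(C(=O)O)c(=O)n21`, holds the lowest of the three numbers recorded in a functional assay on the whole organism for inhibition, with Rattus norvegicus as the target; a lower number here means that less compound is needed, a higher number that more compound is needed for the effect. Compound 1, `CCOC(=O)c1cnc2n(c1=O)C(C)CC/C2=N\Nc1ccccc1C(=O)O`, gives 10 umol/kg in this assay, and compound 3, `C[C@H]1CC/C(=N\Nc2ccc(O)cc2)c2ncc(C(=O)O)c(=O)n21`, gives 111 umol/kg, while compound 2 itself gives 0.5 umol/kg. Both gaps from compound 2 lie beyond the usual scatter, so compound 2 stands as the most potent of the three, with the gap to compound 3 much the wider of the two. Compound 4, `CC1CC/C(=N\Nc2ccc(CC(=O)O)cc2)c2ncc(C(=O)O)c(=O)n21`, is not yet measured in this assay. It differs from compound 2 at one spot: carboxymethyl in place of chloro on an aromatic carbon The new group sits on an aromatic carbon of a six-membered aromatic ring of carbon only, para to a large group. For the measured compounds named here, no measured pair in this set shows the same exchange, so the step is judged from compounds 1 and 3, which carry other groups on the same ring and give weaker numbers. Compound 4 is therefore expected to need more compound than compound 2, with a step of a 40-fold higher number from compound 2 to compound 4 (1.60 log units; beyond the scatter) that goes beyond the scatter. Compound 4 is estimated at 20 umol/kg in this assay, within a range of 3 umol/kg to 150 umol/kg.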

Compound 4, dose for 50% inhibition: 60.9 umol/kg
The estimate for compound 4 lay 3.0-fold (0.48 log units) below the measured number; measured number inside the range.
By their numbers in this assay, from the lowest: compound 2; then compound 1; then compounds 4 and 3 (each within the scatter of the next).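

For the compounds shown here, this pair gives the first step in the set between compounds that differ in one place, and it shows that the aromatic carbon para to a large group is sensitive to what it carries: in this assay, carboxymethyl in place of chloro gives a 120-fold higher number from compound 2 to compound 4 (2.09 log units; beyond the scatter). The change adds heavy atoms, a hydrogen-bond donor and a hydrogen-bond acceptor, and the lower number stays with the single chloro atom. No measurement presented here accounts for this large rise.

This single step cannot separate the effect of the added atoms from that of the terminal acid, so a methyl ester of the same chain or a plain ethyl group at this carbon would bear on the question. As far as these compounds go, the effect of fluoro or bromo in place of chloro also remains open.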